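Swapping an aryl amide for a pyridinylmethyl amide

The compounds below may be only part of what the source reports. "The series", "measured", "known", "first", "only" and "open" are said of these compounds alone.

Three amides built on one shared core have been tested in an ADME assay on HaCaT cells (Homo sapiens) for inhibition; on this read-out higher numbers stand for weaker inhibition and lower numbers for stronger inhibition. Compound 1 `COc1cc(-c2cc(C(=O)O)c3ccccc3n2)ccc1OCC(=O)Nc1cccc(C)c1` gives 225000 nM in this assay. Compound 2 `COc1cc(-c2cc(C(=O)O)c3ccccc3n2)ccc1OCC(=O)Nc1ccc(C)cc1` reaches only the limit of this assay, > 300000 nM, so no number is known for it. Compound 3 `COc1cc(-c2cc(C(=O)O)c3ccccc3n2)ccc1OCC(=O)Nc1ccc(C(F)(F)F)cc1` gives 150000 nM in this assay, and it sits with compound 1 within the scatter: a 1.5-fold lower number from compound 1 to compound 3 (0.18 log units; within the scatter). The step of an at least 1.3-fold higher number from compound 1 to compound 2 (0.12 log units; that floor lies within the scatter) and the step of an at least 2.0-fold lower number from compound 2 to compound 3 (0.30 log units; that floor lies within the scatter) each involve the limit (the limit of > 300000 nM in this assay, at which 1 of the 3 values shown sits), so they set only a floor on the size of the change.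

Compound 4 `COc1cc(-c2cc(C(=O)O)c3ccccc3n2)ccc1OCC(=O)NCc1cccnc1` differs from compound 3 in one place: (pyridin-3-yl)methyl in place of 4-(trifluoromethyl)phenyl on an amide-type nitrogen. For the measured compounds named here, none of the measured steps exchanges an aryl group for an arylmethyl one or brings a ring nitrogen into the amide substituent; the measured steps that exist all stay within or at the edge of the scatter. The expectation for compound 4 in this assay is therefore a number close to that of compound 3, with no step beyond the scatter: a 1.3-fold higher number from compound 3 to compound 4 (0.12 log units; within the scatter). Compound 4 is estimated at 200000 nM, within a range from 90000 nM to 300000 nM, with a real chance that this assay reports only its limit.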

Compound 4, half-maximal inhibitory concentration: > 300000 nM
Compound 4 was reported as a limit; the forecaster's own chance of this, stated with the estimate: 35%; middle value at least 1.5-fold (0.17 log units) from the limit.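

Placing (pyridin-3-yl)methyl on the amide-type nitrogen brings a ring nitrogen and an arylmethyl group into this position for the first time, and in this assay compound 4 gives > 300000 nM, which is a limit of the assay and not a number. Against the two aryl amides that have numbers, the change gives an at least 2.0-fold higher number from compound 3 to compound 4 (0.30 log units; that floor lies within the scatter) and an at least 1.3-fold higher number from compound 1 to compound 4 (0.12 log units; that floor lies within the scatter), so neither comparison shows a lower number for compound 4, though both sizes are only floors. The step between the two limits cannot be read, and the real size of the other steps stays unknown because these values sit at the end of the assay's range: the limit of > 300000 nM in this assay, at which 2 of the 4 values shown sit.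

The compounds shown leave open whether the result goes with the ring nitrogen or with the carbon link, as the change from compound 3 brings in both and also removes the trifluoromethyl group. As far as these compounds go, a benzyl group or a pyridinyl ring joined directly to the same nitrogen would separate these, and whether an amine or a longer chain there gives a number inside the range also remains open.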